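A few compounds are considered here, and "the series" means these few. Any claim that something is new, unique, unknown or untested is made for them only; others in the source may bear on it.

Measured so far:
- compound 1, `Cc1ncnc2c1c(-c1ccsc1)cn2[C@@H]1O[C@H](CO)[C@@H](O)[C@H]1O`: 8560 nM
- compound 2, `CN(C)c1ncnc2c1c(-c1ccsc1)cn2[C@@H]1O[C@H](CO)[C@@H](O)[C@H]1O`: > 20000 nM
- compound 3, `Cc1nc(N)c2c(I)cn([C@@H]3O[C@H](CO)[C@@H](O)[C@H]3O)c2n1`: 3480 nM

In a functional assay on CEM-DNR-bulk cells (Homo sapiens), read by MTT assay, with a stated time of 72 h (a higher number here means a weaker inhibitor, a lower number a stronger inhibitor), compound 3 gives 3480 nM, the lowest of the two plain numbers. Compound 1 gives 8560 nM in this assay. Compound 2 reaches only a limit of this assay, > 20000 nM, and so its value is not a number; this is the limit at the limit of > 20000 nM in this assay, at which 1 of the 3 values shown sits. Within the data shown here, the one measured step, an at least 2.3-fold higher number from compound 1 to compound 2 (0.36 log units; beyond the scatter), therefore has only a lower bound.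

Compound 4, `Cc1nc(N)c2c(-c3ccco3)cn([C@@H]3O[C@H](CO)[C@@H](O)[C@H]3O)c2n1`, differs from compound 3 in one place: furan-2-yl in place of iodo on an aromatic carbon. Among the measured compounds shown here, none of the measured steps covers this exchange, since the measured step concerns a different position and a different pair of groups. For the measured compounds named here, compounds 1 and 2 carry a thiophene ring where compound 3 carries iodo, but they differ from compound 3 elsewhere too, so their values give no single step to lean on. Going by the values given here, with no direct precedent, compound 4 is expected to land near compound 3, with a wide range: 1200 nM, between 200 nM and 7000 nM, a step of a 2.9-fold lower number from compound 3 to compound 4 (0.46 log units; beyond the scatter).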

Compound 4, half-maximal inhibitory concentration: > 20000 nM
Compound 4: no number, only a limit (the forecaster's own chance of this, stated with the estimate: 5%); middle value at least 16-fold (1.22 log units) away from the limit.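

Exchanging iodo for furan-2-yl on this aromatic carbon gives an at least 5.7-fold higher number from compound 3 to compound 4 (0.75 log units; beyond the scatter) in this assay and is the first change shown at this position, since the earlier step concerned a different place. The group on this carbon therefore matters: a five-membered aromatic ring cannot simply stand in for iodo here while the rest of compound 3 stays the same. The size of the step has only a lower bound because the result for compound 4 is a limit, not a number: the limit of > 20000 nM in this assay, at which 2 of the 4 values shown sit.

Only two groups are shown on this carbon with the rest of compound 3 unchanged, so these compounds cannot tell whether the change comes from the furan ring itself or from the loss of iodo. From the compounds shown here alone, how a methyl, an amine or a phenyl ring would read at this position remains open.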